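A few compounds are considered here, and "the series" means these few. Any claim that something is new, unique, unknown or untested is made for them only; others in the source may bear on it.

In a physicochemical assay for solubility, read by HPLC, with a stated time of 24 h (a lower number here means a less soluble compound, a higher number a more soluble compound), compound 3 (`CC(C)(C)c1[nH]cnc1/C=c1\[nH]c(=O)/c(=C/c2cccc(C(=O)c3ccncc3)c2)[nH]c1=O`) stands at < 0.1 ug/mL, which is a limit and not a number. Compound 1 (`CC(C)(C)c1[nH]cnc1/C=c1\[nH]c(=O)/c(=C/c2cccc(C(=O)N3CCCCC3)c2)[nH]c1=O`) gives < 0.1 ug/mL, also a limit. Compound 2 (`O=C(c1cccc(/C=c2\[nH]c(=O)/c(=C/c3ccccn3)[nH]c2=O)c1)N1CCCCC1`) gives < 0.1 ug/mL, again a limit. Within the data shown here, the series so far therefore rests on (the limit of < 0.1 ug/mL in this assay, at which 3 of the 3 values shown sit).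

Compound 4 (`CC(C)(C)c1[nH]cnc1/C=c1\[nH]c(=O)/c(=C/c2cccc(C(=O)c3ccoc3)c2)[nH]c1=O`) has furan-3-yl in place of pyridin-4-yl on a carbonyl carbon.

The closest measured change, also on a carbonyl carbon, is a step that the two limits leave unreadable from compound 1 to compound 3. The other measured change is a step that the two limits leave unreadable from compound 1 to compound 2. Neither gives a size, so no step beyond the scatter and no direction is expected in this assay. The expected step is a number no lower from compound 3 to compound 4 (the limit leaves the size open). Compound 4 is estimated at 0.1 ug/mL, with an expected range of 0.05 ug/mL to 0.4 ug/mL.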

Compound 4, solubility: < 0.1 ug/mL
Compound 4 was reported as a limit; the forecaster's own chance of this, stated with the estimate: 80%; the middle value lies on the limit itself.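

No step can be read from compound 3 or compound 1 to compound 4, since each of these values is a limit and not a number: the limit of < 0.1 ug/mL in this assay, at which 4 of the 4 values shown sit.

The compounds shown leave open the size and direction of every step among them.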